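Ester in Place of the Proline Amide

This account rests on a few compounds, and the source may have more. Where it says the series, first, only, none or still open, it means among the compounds named here.

Compound 1 `CNC(=O)/C=C/c1ccncc1-c1ccc2c(cnn2C)c1` gives 3480 nM in a functional assay on HCT-116 cells (Homo sapiens) for inhibition, read by MTT assay, with a stated time of 72 h; a higher number here means a weaker inhibitor of growth, a lower number a stronger inhibitor of growth. Compound 2 `O=C(O)[C@@H]1CCCN1C(=O)/C=C/c1ccncc1-c1ccc2ccccc2c1` shares the same assay, where compound 2 gives "not determined" (no result reported); no number stands for it. Compound 3 `CCOC(=O)/C=C/c1ccncc1-c1ccc2ccccc2c1` differs from compound 2 in one place: ethoxy in place of 2-carboxypyrrolidin-1-yl on a carbonyl carbon. With no value for compound 2, no direction or size of step can be read for this pair in this assay. For the measured compounds named here, compound 3 is expected to give 3000 nM, within a range of 700 nM to 13000 nM, resting on the only number at hand, that of compound 1.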

Compound 3, concentration for 50% growth inhibition: 910 nM
Compound 3: middle estimate off by 3.3-fold (0.52 log units), on the high side; the measured number falls inside the stated range.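

Compound 2 has no number to set against compound 3, so no step can be read between them. From the compounds shown here alone, what ethoxy in place of 2-carboxypyrrolidin-1-yl does to growth inhibition stays open, and no other evidence bears on this result.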